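Carboxy to ethylcarbamoyl on the benzyl compound

A few compounds are considered here, and "the series" means these few. Any claim that something is new, unique, unknown or untested is made for them only; others in the source may bear on it.

Measured so far in a functional assay on cells (Platelet, Homo sapiens) for inhibition; a lower number here means a stronger inhibitor, a higher number a weaker inhibitor:
- Compound 1 `CCOC(=O)c1ccc(-c2nn(-c3ccco3)c3ccccc23)cc1`: > 10000 nM
- Compound 2 `CCOC(=O)c1ccc(-c2nn(-c3ccoc3)c3ccccc23)cc1`: > 10000 nM
- Compound 3 `O=C(O)c1ccc(-c2nn(Cc3ccccc3)c3ccccc23)cc1`: > 10000 nM

All three entries are limits and not numbers. In this assay, on these data alone, compound 3 gives > 10000 nM, which is a limit, so its true position is unknown.

Compound 4 `CCNC(=O)c1ccc(-c2nn(Cc3ccccc3)c3ccccc23)cc1` differs from compound 3 at a single place: ethylamino in place of hydroxy on a carbonyl carbon. Carboxy becomes ethylcarbamoyl.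

Going by the values given here, the only measured step is a step that the two limits leave unreadable from compound 1 to compound 2. It concerns the group on an aromatic nitrogen rather than this carbonyl carbon, and it has no readable size to carry over. The wider record is the limit of > 10000 nM in this assay, at which 3 of the 3 values shown sit. Among the compounds with values here, no measured compound therefore supports a step of any particular size or direction, and a further limit reading is the likeliest outcome.

The expected change is a step that the limit leaves unreadable from compound 3 to compound 4, with no firm direction expected. The estimate for compound 4 is 20000 nM. The expected range for compound 4 runs from 4000 nM to 60000 nM.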

Compound 4, half-maximal inhibitory concentration: > 10000 nM
Compound 4: no number, only a limit; the forecaster's own chance of this, stated with the estimate: 75%; the middle value lies beyond the limit too.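

Going by these compounds alone, compound 3 and compound 4 both read only as limits in this assay, so no step between them can be read. The compounds shown leave open how carboxy and ethylcarbamoyl compare, and which structure, if any, gives a measurable value: the limit of > 10000 nM in this assay, at which 4 of the 4 values shown sit.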